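This account rests on a few compounds, and the source may have more. Where it says the series, first, only, none or still open, it means among the compounds named here.

Working notes on a small set of styryl compounds tested in a functional assay on MCF7 cells (Homo sapiens) for cytotoxicity, read by MTT assay, with a stated time of 72 h; a lower number here means a stronger inhibitor, a higher number a weaker inhibitor.

Compound 1 `CC(=O)/C=C(O)/C=C/c1ccc(O)c(O)c1` gives 7900 nM in this assay. Compound 2 `COc1ccc(/C=C/C(=O)CC(C)=O)cc1OC` gives 10600 nM. Compound 3 `Cc1cc(/C=C/c2ccc(O)c(O)c2)on1` gives 6300 nM, the lowest of the three figures, though the gaps to compound 1 and to compound 2 are both within the scatter, so the three compounds cannot be separated on these numbers.

Compound 4 `COc1cc(/C=C/c2cc(C)no2)ccc1O` has not yet been measured. It differs from compound 3 by methyl in place of hydrogen on an oxygen on an aromatic ring. Going by the values given here, no measured pair in the set differs by this one change alone. Compound 1 carries two hydroxy groups and compound 2 two methoxy groups on cores that are otherwise different, and their values lie within the scatter of each other, which gives no sign of a step in either direction beyond the scatter. For compound 4 the step from compound 3 is expected to be small, a 1.3-fold higher number from compound 3 to compound 4 (0.10 log units; within the scatter), with the direction left open. Compound 4 is thus estimated at 8000 nM, with a range of 3500 nM to 18000 nM.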

Compound 4, half-maximal inhibitory concentration: 20900 nM
The estimate for compound 4 lay 2.6-fold (0.42 log units) below the measured number, outside the stated range (above it).
By their numbers in this assay, from the lowest: compounds 3, 1, 2 and 4 (each within the scatter of the next, the first and the last beyond it).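

In this assay, methyl in place of hydrogen on an oxygen on an aromatic ring gives a 3.3-fold higher number from compound 3 to compound 4 (0.52 log units; beyond the scatter), a modest step and the first in the set that rests on a single change. The hydroxy to methoxy change on the core of compound 3 therefore goes with a weaker result, which the comparison of compound 1 with compound 2 could not show, as those two differ in their cores as well and lie within the scatter of each other. This holds for one matched pair only, so no general rule for the series follows from it.

The compounds shown leave open whether a longer chain such as ethoxy on the same oxygen, or an amine in place of the hydroxy, would give a like step. No measurement shown explains the rise in the number.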